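A few compounds are considered here, and "the series" means these few. Any claim that something is new, unique, unknown or untested is made for them only; others in the source may bear on it.

Working notes on the series. Among the measured compounds shown here, in a functional assay on B16-F10 cells (Mus musculus) for inhibition, read by MTT assay, with a stated time of 72 h (a higher number here means a weaker inhibitor, a lower number a stronger inhibitor), compound 2 (`CC1(C)CC(NC(=O)Nc2ccccc2Cl)c2cc(Cl)ccc2O1`) gives 20000 nM and is the only compound with a number so far. For compound 1 (`CC1(C)CC(NC(=O)Nc2cccc(Cl)c2)c2cc(Br)ccc2O1`) the entry reads "not determined" (no result reported) and offers no comparison. Compound 3 (`CC1(C)CC(NC(=O)Nc2ccccc2Cl)c2cc(Br)ccc2O1`) carries bromo in place of chloro on an aromatic carbon of compound 2 (bromo in place of chloro on an aromatic carbon). For the measured compounds named here, no measured pair shows this change. In this assay no step beyond the scatter is expected in either direction. The expected step of a 1.1-fold lower number from compound 2 to compound 3 (0.05 log units; within the scatter) stays within that scatter. For compound 3 the estimated value is 18000 nM (range 8000 nM to 40000 nM).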

Compound 3, half-maximal inhibitory concentration: 22000 nM
Compound 3: the middle estimate sits 1.2-fold (0.09 log units) below what was measured; the measured number falls inside the stated range.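

In this assay, among the compounds shown here, the change from chloro to bromo on this aromatic carbon gives a 1.1-fold higher number from compound 2 to compound 3 (0.04 log units; within the scatter) and is the first step read at this position, so the two halogens cannot be told apart on this core. Compound 1 carries no number, so steps to it cannot be read. Nothing at hand explains the result.

Open, going by these compounds, is whether an amine, a methoxy group or a carboxylic acid at this position would give a step beyond the scatter in this assay and whether any change here matters at all.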